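A few compounds are considered here, and "the series" means these few. Any claim that something is new, unique, unknown or untested is made for them only; others in the source may bear on it.

Values measured in an ADME assay on brain (Rattus norvegicus) for protein binding; on this read-out higher numbers stand for a larger free fraction and lower numbers for a smaller free fraction:

- compound 1 `Cn1ccc2c(Cc3ccc(-c4nccs4)cc3)cc(C(=O)N[C@@H]3CCOC[C@H]3O)nc21` gives 0.01
- compound 2 `Cn1ccc(-c2ccc(Cc3cc(C(=O)N[C@@H]4CCCC[C@H]4O)nc4c3ccn4C)cn2)n1` gives 0.04
- compound 3 `Cn1ccc(-c2ccc(Cc3cc(C(=O)NC4CCOCC4)nc4c3ccn4C)cc2)n1` gives 0.01

Compound 3 stands level with compound 1, and the two share the lowest number of the three. Compound 2 lies higher, by a gap beyond the usual scatter.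

The next compound, compound 4 `Cn1ccc(-c2ccc(Cc3cc(C(=O)N[C@@H]4CCOC[C@H]4O)nc4c3ccn4C)cc2)n1`, differs from compound 3 in one place: hydroxy in place of hydrogen on a saturated ring carbon. In words, a hydroxy replaces a hydrogen on a saturated ring carbon, next to the ring atom that bears a large group.

Among the compounds with values here, no measured pair shows this change alone, so the evidence is indirect. Compound 1 already carries the (3-hydroxyoxan-4-yl)carbamoyl group and gives 0.01, which suggests that the hydroxy need not raise the number much. Compound 2 also has a hydroxy on its saturated ring and gives 0.04, which leaves room for a modest rise. A small upward move that stays within the scatter is expected, estimated as a 1.5-fold higher number from compound 3 to compound 4 (0.18 log units; within the scatter). The estimate for compound 4 is 0.015, with an expected range from 0.008 to 0.03.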

Compound 4, unbound fraction: 0.01
For compound 4 the middle estimate is 1.5-fold (0.18 log units) above the measured one; the measured number falls inside the stated range.
By their numbers in this assay, from the lowest: compounds 1, 3 and 4 (each within the scatter of the next); then compound 2.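

In this assay, the hydroxy on this saturated ring carbon, two ring bonds from the ring oxygen, gives no change at the digits printed from compound 3 to compound 4 (within the scatter), so this direct pair shows that the added group leaves the free fraction unmoved on this scaffold. Exchanging 1,3-thiazol-2-yl for 1-methyl-1H-pyrazol-3-yl on an aromatic carbon, with the (3-hydroxyoxan-4-yl)carbamoyl group kept, gives no change at the digits printed from compound 1 to compound 4 (within the scatter), so that change also leaves the number in place in this assay. Nothing measured here offers a cause for either result.

From the compounds shown here alone, whether an amino or a methoxy group on the same ring carbon would shift the number remains open. So does whether the hydroxy would leave it equally unmoved on a saturated ring without the ring oxygen.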